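Aminothiophene ketones as adenosine receptor agonists: halogen swap

This account rests on a few compounds, and the source may have more. Where it says the series, first, only, none or still open, it means among the compounds named here.

The series rests on one shared core, an aminothiophene carrying a ketone, with two aryl groups that vary. Compound 1 is `Nc1scc(-c2ccc(Cl)cc2)c1C(=O)c1ccccc1`, compound 2 is `Nc1scc(-c2cccc(Br)c2)c1C(=O)c1ccccc1`, compound 3 is `Nc1scc(-c2ccc(Cl)cc2)c1C(=O)c1ccc(Cl)cc1`, and compound 4, not yet measured, is `Nc1scc(-c2cccc(Br)c2)c1C(=O)c1ccc(Cl)cc1`. In a functional assay on CHO cells for agonist activity at adenosine receptor A1 (Homo sapiens), read by fluorescence and ERK phosphorylation, with stated times of 30 min and 1.5 h, tested at 3 uM (a higher number here means a stronger effect of the compound at the concentration tested, a lower number a weaker effect), compound 1 gives 46%. In this assay compound 2 gives 67%. In this assay compound 3 gives 50%.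

The change from compound 1 to compound 2 is 3-bromophenyl in place of 4-chlorophenyl on an aromatic carbon; it brought a number 21 percentage points higher from compound 1 to compound 2 (beyond the scatter). The two cores differ as chloro in place of hydrogen on an aromatic carbon, with a number 4 percentage points higher from compound 1 to compound 3 (within the scatter), so compound 1 and compound 3 are not told apart in this assay. The change from compound 3 to compound 4 is 3-bromophenyl in place of 4-chlorophenyl on an aromatic carbon. It is the same kind of change as that from compound 1 to compound 2, though around the place the neighbouring ring atom bears a group of 9 heavy atoms in compound 3 where it bears a group of 8 heavy atoms in compound 1.

Going by the values given here, with only one earlier example of this change, the expectation is that compound 4 shows a step of about a number 18 percentage points higher from compound 3 to compound 4 (beyond the scatter) because a number 21 percentage points higher from compound 1 to compound 2 (beyond the scatter) is the sole guide and the core difference hardly moved the read-out. Compound 4 is thus expected to give 68% in this assay, with the estimate spanning 52% to 82%.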

Compound 4, a percentage reported as activity, at one concentration (the size of the read-out at that concentration, not a potency): 62%
Compound 4: the middle estimate sits 6 percentage points above what was measured, within the range that was stated.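

In this assay, 3-bromophenyl in place of 4-chlorophenyl gave a number 12 percentage points higher from compound 3 to compound 4 (beyond the scatter), so the step has the same direction on both cores and its size does not differ measurably between them: the same change on two cores in this assay, a number 21 percentage points higher (beyond the scatter) from compound 1 to compound 2 and a number 12 percentage points higher (beyond the scatter) from compound 3 to compound 4, 9 percentage points apart, within the scatter of two such steps. Chloro in place of hydrogen gave a number 5 percentage points lower from compound 2 to compound 4 (within the scatter), which leaves this second change without a readable effect on either aryl background: the same change on two cores in this assay, a number 4 percentage points higher (within the scatter) from compound 1 to compound 3 and a number 5 percentage points lower (within the scatter) from compound 2 to compound 4, 9 percentage points apart, within the scatter of two such steps. These notes rest on just two cores that differ by a single chloro, and the read-out is taken at one concentration, so they show neither a potency shift nor that the step would carry over to a core differing more widely.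

The swap changes the halogen and its place on the ring together, and a 3-chlorophenyl or 4-bromophenyl group would be needed to tell which of the two goes with the higher read-out. Also open, on these data alone, is whether the step persists with a methoxy group, an amine or a carboxylic acid in place of the chloro on the aryl ring of the ketone.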